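A few compounds are considered here, and "the series" means these few. Any claim that something is new, unique, unknown or untested is made for them only; others in the source may bear on it.

In a functional assay on CHO-K1 cells for antagonist activity at melanin-concentrating hormone receptor 1 (Homo sapiens), read by inositol phosphate accumulation (on this read-out lower numbers stand for stronger inhibition and higher numbers for weaker inhibition), compound 1 `Cc1nc(N2CCN(C)CC2)nc2ccc(NC(=O)COc3ccc(Cl)cc3)cc12` gives 3800 nM, while compound 2 `Cc1nc(N2CCC(O)CC2)nc2ccc(NC(=O)COc3ccc(Cl)cc3)cc12` gives 163 nM, the lower of the two numbers, the pair separated by a 23-fold lower number from compound 1 to compound 2 (1.37 log units; beyond the scatter). Compound 3 `CCC1(O)CCN(c2nc(C)c3cc(NC(=O)COc4ccc(Cl)cc4)ccc3n2)CC1` departs from compound 2 by ethyl in place of hydrogen on a saturated ring carbon, on a saturated ring carbon of a six-membered non-aromatic ring with one nitrogen, three ring bonds from the ring nitrogen. Going by the values given here, no measured step adds a group to that ring carbon; the only step exchanges one ring for another and does not bear on this change. For compound 3 the expected step is a 1.0-fold higher number from compound 2 to compound 3 (0.02 log units; within the scatter), none beyond the scatter. Compound 3 is estimated at 170 nM, between 50 nM and 600 nM.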

Compound 3, half-maximal inhibitory concentration: 384 nM
Compound 3: middle estimate off by 2.3-fold (0.35 log units), on the low side; the range from low to high includes it.
By their numbers in this assay, from the lowest: compound 2; then compound 3; then compound 1.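

In this assay, going by these compounds alone, exchanging 4-hydroxypiperidin-1-yl for 4-ethyl-4-hydroxypiperidin-1-yl gives a modest weakening (a 2.4-fold higher number from compound 2 to compound 3 (0.37 log units; beyond the scatter)), showing for the first time that this saturated ring carbon responds to an added ethyl. The ethyl-bearing ring still retains part of the advantage over 4-methylpiperazin-1-yl (a 9.9-fold lower number from compound 1 to compound 3 (1.00 log units; beyond the scatter)). Nothing available explains the weakening. On these data alone, whether methyl or a longer chain such as propyl on that ring carbon would follow ethyl remains open. So does the effect of an amine or a carboxylic acid there.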